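Cytotoxicity notes: a fluoro variant of compound 1

The source may hold more compounds than are shown below. What is called first, only, known or untested is meant among the compounds shown, and "the series" means these compounds.

Measured so far:
- compound 1 `COc1cccc(CNCCCNc2ccnc3cc(Cc4ccccc4)ccc23)c1O` gives 5720 nM
- compound 2 `COc1ccc(F)cc1CNCCCNc1ccnc2cc(CC(C)C)ccc12` gives 2900 nM
- compound 3 `COc1ccc(Oc2ccc3c(NCCCNCc4ccco4)ccnc3c2)cc1` gives 5300 nM

In an ADME assay on HepG2 cells (Homo sapiens) for cytotoxicity, read by luminescence, CellTiter-Glo and ATP content, with a stated time of 72 h (a higher number here means that more compound is needed for the effect, a lower number that less compound is needed), compound 1 gives 5720 nM, the highest of the three numbers shown, but compound 3 with 5300 nM and compound 2 with 2900 nM both lie within the usual scatter of it, so the three cannot be ranked. Within the data shown here, compounds 2 and 3 differ from compound 1 in several places at once, and no pair among the measured compounds differs in one place only.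

Compound 4 `COc1cccc(CNCCCNc2ccnc3cc(Cc4ccc(F)cc4)ccc23)c1O` differs from compound 1 by fluoro in place of hydrogen on an aromatic carbon. Among the measured compounds shown here, nothing among the measured compounds shows what fluoro in place of hydrogen on an aromatic carbon does in this assay for this series. For the measured compounds named here, with no such step to lean on, the expectation is none beyond the scatter, in either direction. Compound 4 is therefore expected to give 5000 nM, with a range from 2500 nM to 11000 nM. The expected step of a 1.1-fold lower number from compound 1 to compound 4 (0.06 log units; within the scatter) stays within the scatter.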

Compound 4, half-maximal effective concentration: 4780 nM
Beside the measured number, compound 4's estimate is 1.0-fold (0.02 log units) above it; the range from low to high includes it.
By their numbers in this assay, from the lowest: compounds 2, 4, 3 and 1 (each within the scatter of the next).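

In this assay, among these compounds, the change from benzyl to 4-fluorobenzyl gives a 1.2-fold lower number from compound 1 to compound 4 (0.08 log units; within the scatter) and is the only step so far that differs in one place. For this pair, fluoro in place of hydrogen, para to a large group on a six-membered aromatic ring of carbon only, therefore leaves the two compounds indistinguishable, which compounds 2 and 3 could not show. Nothing at hand explains this result or tests it by another measurement.

As far as these compounds go, whether a carboxylic acid, an amine or a trifluoromethyl group at this same place would also stay within the scatter remains open. Among the compounds shown here, also open is whether fluoro in place of hydrogen gives a similar step on other members, since this single pair is the only reading of the change.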